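Acetyl in place of a hydroxy hydrogen on two cores

The compounds below may be only part of what the source reports. "The series", "measured", "known", "first", "only" and "open" are said of these compounds alone.

Measured so far:
Compound 1, `O=C(Nc1ncc([N+](=O)[O-])s1)c1cc(Cl)cc(Cl)c1O`, gives 100%.
Compound 2, `CC(=O)Oc1c(Cl)cc(Cl)cc1C(=O)Nc1ncc([N+](=O)[O-])s1`, gives 100%.
Compound 3, `CC(C)c1cc(C(=O)Nc2ncc([N+](=O)[O-])s2)c(O)c(C(C)C)c1`, gives 29.4%.

All three were tested in an ADME assay on HEK-293T cells (Homo sapiens) for cytotoxicity, read by MTT assay, tested at 25 uM; a lower number here means a stronger effect, a higher number a weaker effect of the compound at the concentration tested. Compound 1 and compound 2 share a core and differ in one place: acetyl in place of hydrogen on an oxygen on an aromatic ring. That change produced no change at the digits printed from compound 1 to compound 2 (within the scatter). Compound 3 is built on a different core, and the difference between the two cores is not broken down here. In this assay compound 3 stands lowest of the three, and its gap to compound 1 and to compound 2 lies beyond the scatter.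

Compound 4, `CC(=O)Oc1c(C(=O)Nc2ncc([N+](=O)[O-])s2)cc(C(C)C)cc1C(C)C`, has not yet been measured. It is related to compound 3 by the same change that relates compound 1 to compound 2: acetyl in place of hydrogen on an oxygen on an aromatic ring. The place is described in the same words for both pairs, so this is the same change carried over to another core. Among the measured compounds shown here, the only precedent is the step from compound 1 to compound 2, which left the read-out where it was; both of those numbers sit at the top of the range, so that precedent cannot show whether the change would move a lower number. The step from compound 3 to compound 4 is nonetheless expected to be a number 5.6 percentage points higher from compound 3 to compound 4 (within the scatter), small, resting on no change at the digits printed from compound 1 to compound 2 (within the scatter) alone. Compound 4 is therefore estimated to give 35%, within 15% to 70%, the range kept wide for lack of a second example.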

Compound 4, a percentage reported as activity, at one concentration (the size of the read-out at that concentration, not a potency): 45.9%
For compound 4 the middle estimate is 10.9 percentage points below the measured one, within the range that was stated.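

In this assay, acetyl in place of the hydrogen on the oxygen on the aromatic ring gave a number 16.5 percentage points higher from compound 3 to compound 4 (beyond the scatter). Set beside the earlier step, the same change did not behave alike on the two cores: the same change on two cores in this assay, no change at the digits printed (within the scatter) from compound 1 to compound 2 and a number 16.5 percentage points higher (beyond the scatter) from compound 3 to compound 4, 16.5 percentage points apart, beyond the scatter of two such steps. So, in this series, the result of this change on one core could not simply be carried over to the other, but these data do not show why the two steps differ, and with compound 1 and compound 2 both at the top of the range, the flat first step may say little about what the change can do on a core that starts lower; two pairs are also too few to support a general rule about this change.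

The compounds shown leave open whether a different group on that same oxygen, such as a methyl group or a longer acyl chain like butyryl, would follow the acetyl result on either core. They also leave open which part of the two cores sets the steps apart, since the cores differ as a whole and no compound shown stands between them.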